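The compounds below may be only part of what the source reports. "The series", "measured", "known", "first", "only" and "open" are said of these compounds alone.

In a functional assay on RS4-11 cells (Homo sapiens) for inhibition, read by CCK-8 assay, with a stated time of 48 h, tested at 20 uM (a lower number here means less inhibition of growth, a higher number more inhibition of growth at the concentration tested), the measured compounds are:
Compound 1 `COc1ccc(Cc2nnc(NC(=O)/C(C#N)=C/c3ccccc3OS(=O)(=O)c3ccc(OC)cc3)s2)cc1`: 78%
Compound 2 `COc1ccc(Cc2nnc(NC(=O)/C(C#N)=C/c3ccccc3OS(=O)(=O)c3ccc([N+](=O)[O-])cc3)s2)cc1`: 70%
Compound 3 `COc1ccc(S(=O)(=O)Oc2ccccc2/C=C(\C#N)C(=O)Nc2nnc(Cc3ccc(C)cc3)s2)cc1`: 79%

Compound 1 and compound 3 differ in their cores by methyl in place of methoxy on an aromatic carbon, and the step is a number 1 percentage points higher from compound 1 to compound 3 (within the scatter).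

The change from compound 1 to compound 2 is nitro in place of methoxy on an aromatic carbon, which gave a number 8 percentage points lower from compound 1 to compound 2 (within the scatter).

Compound 4 `Cc1ccc(Cc2nnc(NC(=O)/C(C#N)=C/c3ccccc3OS(=O)(=O)c3ccc([N+](=O)[O-])cc3)s2)cc1` has not yet been measured. It differs from compound 3 by nitro in place of methoxy on an aromatic carbon, the same change at the same place as that from compound 1 to compound 2.

The expectation for compound 4 rests on the step of a number 8 percentage points lower from compound 1 to compound 2 (within the scatter), applied to compound 3 at 79%. Compound 4 is therefore expected to give 71% in this assay, with a likely range from 60% to 82%. The expected step is a number 8 percentage points lower from compound 3 to compound 4 (within the scatter), a move of about the same size as the earlier one.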

Compound 4, percent growth inhibition at one concentration: 64%
The estimate for compound 4 lay 7 percentage points above the measured number; measured number inside the range.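

In this assay, nitro in place of methoxy on the core bearing the methyl group gives a number 15 percentage points lower from compound 3 to compound 4 (beyond the scatter), and this step does not differ from the earlier one: the same change on two cores in this assay, a number 8 percentage points lower (within the scatter) from compound 1 to compound 2 and a number 15 percentage points lower (beyond the scatter) from compound 3 to compound 4, 7 percentage points apart, within the scatter of two such steps. Methyl in place of methoxy likewise gives a number 6 percentage points lower from compound 2 to compound 4 (within the scatter), with no difference between the two cores: the same change on two cores in this assay, a number 1 percentage points higher (within the scatter) from compound 1 to compound 3 and a number 6 percentage points lower (within the scatter) from compound 2 to compound 4, 7 percentage points apart, within the scatter of two such steps. Both changes therefore carry between these two cores without a detectable difference, but two pairs do not show that either step has a fixed size or that it would hold on any other core.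

Going by these compounds, whether an amine or a carboxylic acid on that aromatic carbon would give a similar number remains open. So does whether a longer chain in place of methyl or methoxy would do so.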